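A few compounds are considered here, and "the series" means these few. Any claim that something is new, unique, unknown or untested is made for them only; others in the source may bear on it.

The measured compounds:
Compound 1 `CC(=O)NCC[C@@H]1C[C@@H](c2ccc(F)c(F)c2)[C@H](NC(=O)c2cc(-c3c(Cl)cnn3C)c(Cl)o2)CN1` gives 130 nM in a functional assay on LNCaP cells (Homo sapiens) for antiproliferative activity; on this read-out lower numbers stand for stronger inhibition and higher numbers for weaker inhibition.
Compound 2 `CC(=O)OCC[C@@H]1C[C@@H](c2ccc(F)c(F)c2)[C@H](NC(=O)c2cc(-c3c(Cl)cnn3C)c(Cl)o2)CN1` gives "not determined" (no result reported) in this assay.
Compound 3 `CNC(=O)C[C@@H]1C[C@@H](c2ccc(F)c(F)c2)[C@H](NC(=O)c2cc(-c3c(Cl)cnn3C)c(Cl)o2)CN1` gives 50 nM in this assay.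

Among the measured compounds shown here, compound 3 holds the lowest of the two numbers; the only measured step is a 2.6-fold lower number from compound 1 to compound 3 (0.41 log units; beyond the scatter), modest and beyond the scatter. Compound 4 `Cn1ncc(Cl)c1-c1cc(C(=O)N[C@@H]2CN[C@H](CC(O)CO)C[C@H]2c2ccc(F)c(F)c2)oc1Cl` differs from compound 3 by 1,2-dihydroxyethyl in place of methylcarbamoyl on a saturated chain carbon bound to a saturated ring carbon. That single step is the only one touching this place, and it compared acetamidomethyl with methylcarbamoyl, not 1,2-dihydroxyethyl, so it offers little direct guidance. Compound 4 is therefore expected to move only slightly, with a 1.6-fold higher number from compound 3 to compound 4 (0.20 log units; within the scatter) most likely within the scatter, if anything toward a higher number. The estimate for compound 4 in this assay is 80 nM, with a range from 30 nM to 250 nM.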

Compound 4, half-maximal inhibitory concentration: 100 nM
Beside the measured number, compound 4's estimate is 1.3-fold (0.10 log units) below it; the measured number falls inside the stated range.
By their numbers in this assay, from the lowest: compounds 3, 4 and 1 (each within the scatter of the next, the first and the last beyond it).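

In this assay the change to 1,2-dihydroxyethyl reads the same way against both earlier groups: from methylcarbamoyl it gives (a 2.0-fold higher number from compound 3 to compound 4 (0.30 log units; within the scatter)), and from acetamidomethyl it gives (a 1.3-fold lower number from compound 1 to compound 4 (0.11 log units; within the scatter)). A group with no nitrogen and no double bond outside aromatic rings thus stays within the scatter of both amide-bearing compounds on this saturated chain carbon, which the earlier comparison of two amides could not show. Nothing available here explains why these groups read alike. On these data alone, whether a primary amine, a carboxylic acid or a longer chain at this place would stay in this range remains open.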